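Swapping 2-(Trifluoromethyl)phenyl for Quinolin-8-yl

The source may report more compounds than this note shows. Statements on the series, on what has been measured and on what is new or still open speak of the compounds shown alone.

In a functional assay on Shh Light II cells (Mus musculus) for inhibition, read by a luciferase reporter (on this read-out higher numbers stand for weaker inhibition and lower numbers for stronger inhibition), compound 1 `O=C(NC1CCNCC1)N1CCC(c2nc(-c3ccc4ccccc4n3)no2)CC1` gives 2500 nM, while compound 2 `O=C(Nc1ccccc1C(F)(F)F)N1CCC(c2nc(-c3ccc4ccccc4n3)no2)CC1` gives 700 nM. Among the measured compounds shown here, compound 2 therefore holds the lower of the two numbers measured so far, which means the stronger inhibition.

The next structure is compound 3 `O=C(Nc1cccc2cccnc12)N1CCC(c2nc(-c3ccc4ccccc4n3)no2)CC1`, with quinolin-8-yl in place of 2-(trifluoromethyl)phenyl on an amide-type nitrogen. The swap keeps an aromatic ring of carbon only on that nitrogen, but it adds a second aromatic ring that holds a hetero atom.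

For the measured compounds named here, one measured step bears on this site: a 3.6-fold lower number from compound 1 to compound 2 (0.55 log units; beyond the scatter). That modest change replaced piperidin-4-yl with 2-(trifluoromethyl)phenyl, so it shows that this site can shift the number, but it says nothing direct about quinolin-8-yl. Since the new swap exchanges one aromatic group for another, a smaller shift seems likely, and the data give no firm direction. The expected change is a 1.2-fold lower number from compound 2 to compound 3 (0.07 log units; within the scatter), with no step beyond the scatter anticipated. For compound 3 the estimated value is 600 nM, with an expected range of 200 nM to 1800 nM.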

Compound 3, half-maximal inhibitory concentration: 1400 nM
The estimate for compound 3 lay 2.3-fold (0.37 log units) below the measured number, within the range that was stated.
By their numbers in this assay, from the lowest: compounds 2, 3 and 1 (each within the scatter of the next, the first and the last beyond it).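

In this assay quinolin-8-yl on the amide-type nitrogen cannot be told apart from 2-(trifluoromethyl)phenyl, with a 2.0-fold higher number from compound 2 to compound 3 (0.30 log units; within the scatter), and it cannot be told apart from piperidin-4-yl either, with a 1.8-fold lower number from compound 1 to compound 3 (0.25 log units; within the scatter). Among the compounds shown here, the earlier pair showed only that the group on this nitrogen can shift the number, whereas compound 3 lies within the scatter of both compound 1 and compound 2, even though those two lie beyond the scatter of each other, so it cannot be assigned to either side of that gap. Adding a ring with a hetero atom and a hydrogen-bond acceptor at this position therefore gives no clear gain or loss in inhibition, and nothing available here explains the result.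

Going by these compounds, it remains open whether the ring nitrogen of quinolin-8-yl matters at all, a question that a naphthalen-1-yl group on the same nitrogen could help to settle. On these data alone, it is also open whether a plain phenyl group, or a chain ending in a carboxylic acid, would move the number beyond the scatter in either direction.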